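Furan to Hydroxymethoxyphenyl on Two Cores: Cytotoxicity

This account rests on a few compounds, and the source may have more. Where it says the series, first, only, none or still open, it means among the compounds named here.

Measured compounds and values:
compound 1 `Fc1ccc(Oc2ccc3c(NCCCNCc4ccco4)ccnc3c2)cc1`: 16000 nM
compound 2 `FC(F)(F)c1cc(-c2ccc3c(NCCCNCc4ccco4)ccnc3c2)cc(C(F)(F)F)c1`: 2410 nM
compound 3 `COc1cccc(CNCCCNc2ccnc3cc(Oc4ccc(F)cc4)ccc23)c1O`: 11000 nM

Of the compounds shown here, three have been measured in an ADME assay on HepG2 cells (Homo sapiens) for cytotoxicity, read by luminescence, CellTiter-Glo and ATP content, with a stated time of 72 h; a higher number here means that more compound is needed for the effect, a lower number that less compound is needed. Compound 1 and compound 3 share one core and differ in a single place: 2-hydroxy-3-methoxyphenyl in place of furan-2-yl on a saturated chain carbon bound to an amine nitrogen. That change gave a 1.5-fold lower number from compound 1 to compound 3 (0.16 log units; within the scatter), so the two values are treated as the same within the scatter of this assay. Compound 2 carries a different core, and the difference between the two cores is not broken down here; what can be said is that compound 2 gives the lowest of the three numbers, and that its steps to compound 3 and to compound 1 both lie beyond the scatter.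

Compound 4 `COc1cccc(CNCCCNc2ccnc3cc(-c4cc(C(F)(F)F)cc(C(F)(F)F)c4)ccc23)c1O` has not yet been measured in this assay. It stands to compound 2 as compound 3 stands to compound 1: 2-hydroxy-3-methoxyphenyl in place of furan-2-yl on a saturated chain carbon bound to an amine nitrogen. The place of the change is the same in both pairs, so this is the same change made on the second core.

Because a 1.5-fold lower number from compound 1 to compound 3 (0.16 log units; within the scatter) was within the scatter, the expectation for compound 4 is that the step from compound 2 will again be small, and the author expects a 1.3-fold lower number from compound 2 to compound 4 (0.13 log units; within the scatter). This rests on one earlier pair only, so the range is kept wide. Compound 4 is therefore estimated at 1800 nM, expected to fall between 700 nM and 4500 nM.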

Compound 4, half-maximal effective concentration: 940 nM
Compound 4: the middle estimate sits 1.9-fold (0.28 log units) above what was measured; measured number inside the range.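

In this assay, the change from furan-2-yl to 2-hydroxy-3-methoxyphenyl on the second core gave a 2.6-fold lower number from compound 2 to compound 4 (0.41 log units; beyond the scatter), a modest step that goes the same way as the one on the first core. Set side by side, the two steps cannot be told apart, so in this series the change carries over from one core to the other with no measurable difference in size: the same change on two cores in this assay, a 1.5-fold lower number (0.16 log units; within the scatter) from compound 1 to compound 3 and a 2.6-fold lower number (0.41 log units; beyond the scatter) from compound 2 to compound 4, 1.8-fold (0.25 log units) apart, within the scatter of two such steps This does not show that the larger number of the second step reflects a real effect of the core, and two pairs cannot establish that the change would behave alike on any further core.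

The compounds shown leave open which part of 2-hydroxy-3-methoxyphenyl goes with the step from furan-2-yl, which a plain phenyl, or a phenyl carrying only the hydroxy group or only the methoxy group, would help to separate. They also leave open whether the same change would give a similar step with a longer chain linking the two amine nitrogens, or on a third core.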